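Swapping the amide substituent on a shared thienopyran core

A few compounds are considered here, and "the series" means these few. Any claim that something is new, unique, unknown or untested is made for them only; others in the source may bear on it.

Two compounds share a core and differ only in the group attached to the carbonyl carbon of the amide. Compound 1 `CC1(C)Cc2c(sc(NC(=O)c3cn[nH]c3)c2C(N)=O)C(C)(C)O1` carries a 1H-pyrazol-4-yl there; in an assay on cells for positive allosteric modulation of Cystic fibrosis transmembrane conductance regulator variant F508del (Homo sapiens), with stated times of 10 min and 7 s, in the presence of a further agent that is not named here (a higher number here means that more compound is needed for the effect, a lower number that less compound is needed), compound 1 gives 125 nM. Compound 2 `CC1(C)Cc2c(sc(NC(=O)[C@H](O)C(C)(C)C)c2C(N)=O)C(C)(C)O1` carries a 1-hydroxy-2,2-dimethylpropyl instead, and in this assay compound 2 gives 127 nM. The step of a 1.0-fold higher number from compound 1 to compound 2 (0.01 log units; within the scatter) shows that this exchange left the result essentially unchanged, and compound 2 sits level with compound 1 rather than apart from it. Compound 3 `CC1(C)Cc2c(sc(NC(=O)c3[nH]ncc3Cl)c2C(N)=O)C(C)(C)O1` returns to a ring: a group of 6 heavy atoms (3 carbon, 2 nitrogen, 1 chlorine; one five-membered aromatic ring with 2 hetero atoms) in place of a group of 6 heavy atoms (5 carbon, 1 oxygen; no ring), on a carbonyl carbon. For the measured compounds named here, only the one measured step bears on this change, and it was flat, so the expectation is for little movement, giving an estimated step of a 1.1-fold lower number from compound 2 to compound 3 (0.02 log units; within the scatter). Compound 3 is therefore expected to give about 120 nM, with a likely range from 45 nM to 320 nM.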

Compound 3, half-maximal effective concentration: 2 nM
Beside the measured number, compound 3's estimate is 60-fold (1.78 log units) above it, outside the stated range (below it).
By their numbers in this assay, from the lowest: compound 3; then compounds 1 and 2 (each within the scatter of the next).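

The earlier pair made this position, on a carbonyl carbon whose other neighbour is an amide-type nitrogen, look unresponsive, but in this assay the change shows a 64-fold lower number from compound 2 to compound 3 (1.80 log units; beyond the scatter) and so reveals that the result can depend strongly on the group placed here. Heavy-atom count does not separate these groups, since the leaving and entering groups each have 6 heavy atoms. Having a five-membered aromatic ring with 2 hetero atoms is not enough either: compound 1 has such a ring too, yet the comparison gives a 63-fold lower number from compound 1 to compound 3 (1.80 log units; beyond the scatter) and so points to the differences between the two rings, namely the chlorine and the ring's point of attachment.

These compounds cannot separate those two differences, and a methyl group or a nitrile in place of the chlorine would help show whether chlorine itself matters. Nothing available here explains why the number falls so far.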